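Changing the Chain on a Weakly Active Core

The source may report more compounds than this note shows. Statements on the series, on what has been measured and on what is new or still open speak of the compounds shown alone.

Compound 1 `COc1cc(Cc2nc3c(N)ncnc3n2CC2CCCCC2)cc(OC)c1OC`: 39800 nM
Compound 2 `CCCCCn1c(Cc2cc(OC)c(OC)c(OC)c2)nc2c(N)ncnc21`: 61700 nM
Compound 3 `CC/C=C\Cn1c(Cc2cc(OC)c(OC)c(OC)c2)nc2c(N)ncnc21`: 64600 nM

All three compounds share one core and differ only in the chain on a saturated chain carbon bound to an aromatic nitrogen. In a functional assay on MCF7 cells (Homo sapiens) for antiproliferative activity (on this read-out lower numbers stand for stronger inhibition and higher numbers for weaker inhibition), compound 3 gives the highest of the three numbers, yet the gaps to the others are small: a 1.6-fold higher number from compound 1 to compound 3 (0.21 log units; within the scatter) and a 1.0-fold higher number from compound 2 to compound 3 (0.02 log units; within the scatter), both within the scatter, so no order among them can be claimed.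

Compound 4 `COCCn1c(Cc2cc(OC)c(OC)c(OC)c2)nc2c(N)ncnc21` carries the change (methoxymethyl in place of but-1-en-1-yl on a saturated chain carbon bound to an aromatic nitrogen). Within the data shown here, the steps that bear on it are the three changes already made at the same place: a 1.6-fold higher number from compound 1 to compound 2 (0.19 log units; within the scatter), a 1.6-fold higher number from compound 1 to compound 3 (0.21 log units; within the scatter) and a 1.0-fold higher number from compound 2 to compound 3 (0.02 log units; within the scatter), none of them beyond the scatter. Replacing one chain with another here has so far left the number essentially unchanged, so the step from compound 3 to compound 4 is expected to be small: a 1.1-fold lower number from compound 3 to compound 4 (0.03 log units; within the scatter). For compound 4 the estimated value in this assay is 60000 nM, with an expected range from 25000 nM to 140000 nM.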

Compound 4, half-maximal inhibitory concentration: 64600 nM
Compound 4: middle estimate off by 1.1-fold (0.03 log units), on the low side; measured number inside the range.
By their numbers in this assay, from the lowest: compounds 1, 2, 3 and 4 (each within the scatter of the next).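

Compound 4 puts the first oxygen into this chain, and with it one hydrogen-bond acceptor where the but-1-en-1-yl of compound 3 has none, yet the number in this assay stays put (no change at the digits printed from compound 3 to compound 4 (within the scatter)). The two other comparisons read the same way (a 1.0-fold higher number from compound 2 to compound 4 (0.02 log units; within the scatter); a 1.6-fold higher number from compound 1 to compound 4 (0.21 log units; within the scatter)), so on a saturated chain carbon bound to an aromatic nitrogen, cyclohexyl, butyl, but-1-en-1-yl and methoxymethyl all lie within the scatter of one another. Nothing available explains why these chains read alike.

Still open, as far as these compounds go, is whether any group at this place can move the number beyond the scatter, for example an amine, a carboxylic acid or a much longer chain. The four compounds also share the rest of the core, so they cannot show whether changes elsewhere would alter the number.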